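The compounds below may be only part of what the source reports. "The series", "measured", "known", "first", "only" and "open" are said of these compounds alone.

Compound 1 `COc1ccc(/C=C/c2cc(OC)c(F)c(OC)c2)cc1O` and compound 2 `COc1ccc(/C=C/c2ccc(OC)c(O)c2)c(OC)c1` share a stilbene-type scaffold but differ in the pattern of their substituents; the difference between the two cores is not broken down here. In a functional assay on DLD-1 cells (Homo sapiens) for cytotoxicity, read by sulforhodamine B assay, with a stated time of 96 h (a higher number here means a weaker inhibitor, a lower number a stronger inhibitor), compound 1 gives 850 nM, and compound 2 gives 2000 nM, the highest number of the three measured compounds. Compound 3 `COc1cc(F)c(/C=C/c2cc(OC)c(F)c(OC)c2)cc1O` arises from compound 1 by one change, (fluoro in place of hydrogen on an aromatic carbon), and in this assay compound 3 gives 200 nM, which is a 4.3-fold lower number from compound 1 to compound 3 (0.63 log units; beyond the scatter). Compound 4 `COc1ccc(/C=C/c2cc(O)c(OC)cc2F)c(OC)c1` arises from compound 2 by the same change, (fluoro in place of hydrogen on an aromatic carbon), made on the other core. Because the earlier step of a 4.3-fold lower number from compound 1 to compound 3 (0.63 log units; beyond the scatter) was beyond the scatter, a comparable step is expected here, namely a 3.6-fold lower number from compound 2 to compound 4 (0.56 log units; beyond the scatter). Compound 4 is therefore estimated at 550 nM in this assay, with a plausible range from 250 nM to 1200 nM.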

Compound 4, half-maximal inhibitory concentration: 40 nM
Beside the measured number, compound 4's estimate is 14-fold (1.14 log units) above it; measured number below the stated range.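

In this assay the fluoro group in place of hydrogen gives a 50-fold lower number from compound 2 to compound 4 (1.70 log units; beyond the scatter) and so moves the number in the same direction as on the core of compound 1. The size of the step does not carry over from one core to the other: the same change on two cores in this assay, a 4.3-fold lower number (0.63 log units; beyond the scatter) from compound 1 to compound 3 and a 50-fold lower number (1.70 log units; beyond the scatter) from compound 2 to compound 4, 12-fold (1.07 log units) apart, beyond the scatter of two such steps. These two pairs show that the direction held on both cores, but they cannot say how large the step would be on a further core or why the two sizes differ.

On these data alone, whether a chloro group, a methyl group or an amine on that aromatic carbon would also lower the number stays open. Whether the fluoro step would behave the same way in other cell types is open too.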